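Swapping the aryl amine in a trifluoromethylbenzylthio quinazoline series

The source may report more compounds than this note shows. Statements on the series, on what has been measured and on what is new or still open speak of the compounds shown alone.

Compound 1, `CCCCCCCCCCCCNc1nc(SCc2ccc(C(F)(F)F)cc2)nc2ccccc12`: in a functional assay on MGC-803 cells (Homo sapiens) for cytotoxicity, read by MTT assay, with a stated time of 72 h (a higher number here means a weaker inhibitor, a lower number a stronger inhibitor), compound 1 gives > 50000 nM, which is a limit of the assay.
Compound 2, `CCCCCCCCCCCCCCNc1nc(SCc2ccc(C(F)(F)F)cc2)nc2ccccc12`: in this assay compound 2 gives > 50000 nM, again only a limit.
Compound 3, `COc1ccccc1Nc1nc(SCc2ccc(C(F)(F)F)cc2)nc2ccccc12`: in this assay compound 3 gives > 50000 nM, also a limit.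

Within the data shown here, compound 3 therefore stands where every compound measured so far stands, at the limit of > 50000 nM in this assay, at which 3 of the 3 values shown sit. Among the measured compounds shown here, the one pair differing in a single place gives a step that the two limits leave unreadable from compound 1 to compound 2, so no readable step exists. Compound 4, `FC(F)(F)c1ccc(CSc2nc(Nc3ccc(Cl)cc3)c3ccccc3n2)cc1`, differs from compound 3 by 4-chlorophenyl in place of 2-methoxyphenyl on a nitrogen on an aromatic ring. No measured step bears on this change, and nothing shown points away from the limit. Compound 4 is estimated at 60000 nM, between 10000 nM and 200000 nM, an expected step that the limit leaves unreadable from compound 3 to compound 4.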

Compound 4, half-maximal inhibitory concentration: 16800 nM
Estimate against measurement, compound 4: 3.6-fold (0.55 log units) above, and the stated range covers the measured number.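

In this assay, the group on the nitrogen proves able to shift the result: 4-chlorophenyl in place of 2-methoxyphenyl gives an at least 2.9-fold lower number from compound 3 to compound 4 (0.47 log units; beyond the scatter). From the compounds shown here alone, compound 3 gives only a limit, and the true size of this step therefore stays unknown. Compound 4 is the only compound shown with a measured number rather than a limit: the limit of > 50000 nM in this assay, at which 3 of the 4 values shown sit.

The change swaps both the ring's substituent and its ring position, and the step cannot be assigned to either alone. Going by these compounds, what 4-methoxyphenyl, 2-chlorophenyl or plain phenyl would give on that nitrogen remains open.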